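Does bromo lower the number of compound 2?

The source may hold more compounds than are shown below. What is called first, only, known or untested is meant among the compounds shown, and "the series" means these compounds.

The values in a functional assay on T47D cells (Homo sapiens) for inhibition, read by sulforhodamine B assay, with a stated time of 48 h (a lower number here means a stronger inhibitor of growth, a higher number a weaker inhibitor of growth), are as follows
- compound 1 `COC(=[Se])Nc1ccc2c(C)cc(=O)oc2c1` gives > 100000 nM (a limit of the assay, not a number)
- compound 2 `Cc1cc(=O)oc2cc(NC(=[Se])Nc3ccccc3)ccc12` gives 24000 nM (a number)

Among the compounds with values here, compound 2 holds the only actual number so far. Compound 3 `Cc1cc(=O)oc2cc(NC(=[Se])Nc3ccc(Br)cc3)ccc12` has bromo in place of hydrogen on an aromatic carbon of compound 2 (bromo in place of hydrogen on an aromatic carbon). Within the data shown here, one measured step bears on this, and only loosely: anilino in place of methoxy gave an at least 4.1-fold lower number from compound 1 to compound 2 (0.61 log units; beyond the scatter) in this assay and that anilino group is where bromo enters. A modest move to a lower number is therefore expected, estimated as a 2.0-fold lower number from compound 2 to compound 3 (0.30 log units; within the scatter) in this assay at most loosely supported. For compound 3 the expected value is 12000 nM (estimated range 4000 nM to 35000 nM).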

Compound 3, concentration for 50% growth inhibition: 2800 nM
Compound 3: the middle estimate sits 4.3-fold (0.63 log units) above what was measured, and the stated range ends above it.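

In this assay, changing phenyl to 4-bromophenyl gives an 8.6-fold lower number from compound 2 to compound 3 (0.93 log units; beyond the scatter), so growth inhibition responds clearly to a single heavy atom added to this aromatic ring. This step joins two actual numbers, which the earlier step could not do. Compound 1 stands at a limit of the assay, not a number: the limit of > 100000 nM in this assay, at which 1 of the 3 values shown sits.

Going by these compounds, whether chloro, methyl or an amine at this place would give a similar step stays open. So does whether bromo on another carbon of this ring would match compound 3.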